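This account rests on a few compounds, and the source may have more. Where it says the series, first, only, none or still open, it means among the compounds named here.

Measured compounds in this series:

compound 1 `O=S(=O)(c1ccc(F)cc1)c1cc(Cl)c(O)c2ncccc12`: 0.23 L/kg
compound 2 `O=S(=O)(c1ccc(F)cc1)c1cc(F)c(O)c2ncccc12`: 3.5 L/kg
compound 3 `O=S(=O)(c1cc(F)c(O)c2ncccc12)N1CCCC1`: 2.2 L/kg

In an ADME assay on the whole organism for pharmacokinetics, with Rattus norvegicus as the target (on this read-out higher numbers stand for wider distribution into tissues and lower numbers for narrower distribution), compound 2 gives 3.5 L/kg, while compound 1 gives 0.23 L/kg; the change is chloro in place of fluoro on an aromatic carbon and it made a 15-fold lower number from compound 2 to compound 1 (1.18 log units; beyond the scatter). Compound 3 gives 2.2 L/kg in this assay; its core differs from that of compound 2 by pyrrolidin-1-yl in place of 4-fluorophenyl on a sulfonyl sulfur, which made a 1.6-fold lower number from compound 2 to compound 3 (0.20 log units; within the scatter).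

Compound 4 `O=S(=O)(c1cc(Cl)c(O)c2ncccc12)N1CCCC1` remains to be measured in this assay. It differs from compound 3 by chloro in place of fluoro on an aromatic carbon. This is the same kind of change as from compound 2 to compound 1, though the surroundings are described as meta to a group of 8 heavy atoms in one case and meta to a large group in the other. The expectation rests on a single pair: given a 15-fold lower number from compound 2 to compound 1 (1.18 log units; beyond the scatter), compound 4 is expected to fall by about a 7.3-fold lower number from compound 3 to compound 4 (0.87 log units; beyond the scatter). Compound 4 is estimated at 0.3 L/kg, between 0.1 L/kg and 1 L/kg.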

Compound 4, volume of distribution at steady state: 0.8 L/kg
Compound 4: middle estimate off by 2.7-fold (0.43 log units), on the low side; the measured number falls inside the stated range.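

Chloro in place of fluoro gives a lower number on both cores in this assay and here makes a 2.8-fold lower number from compound 3 to compound 4 (0.44 log units; beyond the scatter) but the size of the step does not carry over: the same change on two cores in this assay, a 15-fold lower number (1.18 log units; beyond the scatter) from compound 2 to compound 1 and a 2.8-fold lower number (0.44 log units; beyond the scatter) from compound 3 to compound 4, 5.5-fold (0.74 log units) apart, beyond the scatter of two such steps. Pyrrolidin-1-yl in place of 4-fluorophenyl makes a 3.5-fold higher number from compound 1 to compound 4 (0.54 log units; beyond the scatter) and does not carry over between the chloro and fluoro compounds either: the same change on two cores in this assay, a 1.6-fold lower number (0.20 log units; within the scatter) from compound 2 to compound 3 and a 3.5-fold higher number (0.54 log units; beyond the scatter) from compound 1 to compound 4, 5.5-fold (0.74 log units) apart, beyond the scatter of two such steps. Across these four compounds, the size of each step depends on the group at the other place, but the two pairs of steps show only that they differ, not why.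

On these data alone, it remains open whether bromo or methyl in place of fluoro would follow the larger or the smaller step. The same holds for morpholine or dimethylamino on the sulfonyl sulfur.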